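Swapping an isopropyl for a carboxyhexyl chain

The source may report more compounds than this note shows. Statements on the series, on what has been measured and on what is new or still open speak of the compounds shown alone.

Of the compounds shown here, three built on one shared core have been measured in an assay (Cricetulus griseus) for inhibition of aldehyde dehydrogenase, mitochondrial (Homo sapiens); on this read-out higher numbers stand for weaker inhibition and lower numbers for stronger inhibition. Compound 1 `O=c1c(-c2ccc(O)cc2)coc2cc(OCCOCCOCCO)ccc12` gives 40 nM. Compound 2 `CCOc1ccc2c(=O)c(-c3ccc(O)cc3)coc2c1` gives 80 nM, and compound 3 `CC(C)Oc1ccc2c(=O)c(-c3ccc(O)cc3)coc2c1` gives 80 nM. Compound 3 thus stands level with compound 2, the two together holding the highest numbers of the three, and its separation from compound 1, the step of a 2.0-fold higher number from compound 1 to compound 3 (0.30 log units; within the scatter), lies within the scatter.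

Compound 4 `O=C(O)CCCCCCOc1ccc2c(=O)c(-c3ccc(O)cc3)coc2c1` has not yet been measured. It differs from compound 3 by 6-carboxyhexyl in place of isopropyl on an oxygen on an aromatic ring. Every change made so far at this same oxygen stayed within the scatter: the step of a 2.0-fold higher number from compound 1 to compound 2 (0.30 log units; within the scatter), the step of a 2.0-fold higher number from compound 1 to compound 3 (0.30 log units; within the scatter) and the step of no change at the digits printed from compound 2 to compound 3 (within the scatter). Among the compounds with values here, the new chain ends in a carboxylic acid, which none of the measured compounds carries, so there is no direct precedent for that feature. Compound 4 is nonetheless expected to show a 1.3-fold lower number from compound 3 to compound 4 (0.12 log units; within the scatter), a step no larger than the scatter. Compound 4 is estimated at 60 nM, with a range from 25 nM to 150 nM.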

Compound 4, half-maximal inhibitory concentration: 50 nM
Beside the measured number, compound 4's estimate is 1.2-fold (0.08 log units) above it, and the stated range covers the measured number.
By their numbers in this assay, from the lowest: compounds 1, 4, 2 and 3 (each within the scatter of the next).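

At this oxygen on an aromatic ring, a much larger group ending in a carboxylic acid, 6-carboxyhexyl with 9 heavy atoms against the 3 of isopropyl, still leaves this assay within the scatter: a 1.6-fold lower number from compound 3 to compound 4 (0.20 log units; within the scatter). The other two comparisons agree, with a 1.6-fold lower number from compound 2 to compound 4 (0.20 log units; within the scatter) and a 1.3-fold higher number from compound 1 to compound 4 (0.10 log units; within the scatter), so adding the acid-ended chain gives no measurable change relative to any of the three earlier groups. Nothing available explains why the number stays so steady across these chains.

Going by these compounds, whether the acid end matters at all stays open, and a plain hexyl chain or the methyl ester of the acid would address that. On these data alone, an amine at the end of the same chain would test a different end group, and it also remains open whether any group on this oxygen can move the number beyond the scatter.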